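Open-chain amide in place of the side-chain azole

A few compounds are considered here, and "the series" means these few. Any claim that something is new, unique, unknown or untested is made for them only; others in the source may bear on it.

Compound 1 `CC(C)C(c1ncco1)c1ccc(-c2ccc3cccc(F)c3c2)[nH]c1=O`, compound 2 `CC(C)C(c1nnc[nH]1)c1ccc(-c2ccc3cccc(F)c3c2)[nH]c1=O` and compound 3 `CC(C)C(c1ncc[nH]1)c1ccc(-c2ccc3cccc(F)c3c2)[nH]c1=O` share one core and differ only in the ring carried on the saturated chain carbon bound to an aromatic carbon and a saturated chain carbon. In an assay on CHO cells for displacement of a labelled ligand from prostaglandin E2 receptor EP3 subtype (Homo sapiens), read by radioligand binding (on this read-out higher numbers stand for weaker inhibition and lower numbers for stronger inhibition), compound 1 gives 24 nM, compound 2 gives 12 nM and compound 3 gives 7.3 nM. Compound 3 sits at the lowest of the three numbers, though a 1.6-fold lower number from compound 2 to compound 3 (0.22 log units; within the scatter) while a 3.3-fold lower number from compound 1 to compound 3 (0.52 log units; beyond the scatter). Compound 4 `CC(C)C(CC(N)=O)c1ccc(-c2ccc3cccc(F)c3c2)[nH]c1=O` differs from compound 3 by carbamoylmethyl in place of 1H-imidazol-2-yl on a saturated chain carbon bound to an aromatic carbon and a saturated chain carbon. The measured steps of a 2.0-fold lower number from compound 1 to compound 2 (0.30 log units; within the scatter), a 3.3-fold lower number from compound 1 to compound 3 (0.52 log units; beyond the scatter) and a 1.6-fold lower number from compound 2 to compound 3 (0.22 log units; within the scatter) each trade one five-membered ring for another; none replaces the ring by a chain, so they bound the change only loosely. For compound 4 in this assay a modestly higher number is expected: a 4.1-fold higher number from compound 3 to compound 4 (0.61 log units; beyond the scatter). Compound 4 is estimated at 30 nM, within 8 nM to 120 nM.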

Compound 4, inhibition constant: 5 nM
Compound 4: middle estimate off by 6.0-fold (0.78 log units), on the high side; the whole stated range lies above it.
By their numbers in this assay, from the lowest: compounds 4, 3, 2 and 1 (each within the scatter of the next, the first and the last beyond it).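

In this assay, a ring is not needed at this position among the compounds shown: carbamoylmethyl, which has no ring, stays within the scatter of 1H-imidazol-2-yl, with a 1.5-fold lower number from compound 3 to compound 4 (0.16 log units; within the scatter) as the step. The same open-chain amide lies beyond the scatter of both other azoles, with a 2.4-fold lower number from compound 2 to compound 4 (0.38 log units; beyond the scatter) and a 4.8-fold lower number from compound 1 to compound 4 (0.68 log units; beyond the scatter) as the steps. No supporting evidence bears on this result.

On these data alone, whether the primary amide itself matters stays open, since a carboxymethyl group would test that directly. A carbamoylethyl chain would show whether this position accepts a longer chain.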